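This account rests on a few compounds, and the source may have more. Where it says the series, first, only, none or still open, it means among the compounds named here.

Measured compounds:
Compound 1, `C=CCn1c(=O)/c(=C\c2ccccc2Cl)[nH]c(=O)/c1=C\c1ccccc1OC`: 2500 nM in a functional assay on K562 cells (Homo sapiens) for cytotoxicity, read by CCK-8 assay, with a stated time of 72 h; a higher number here means a weaker inhibitor, a lower number a stronger inhibitor
Compound 2, `C=CCn1c(=O)/c(=C\c2cc(F)ccc2C)[nH]c(=O)/c1=C\c1ccccc1OC`: 1800 nM in this assay

Within the data shown here, of the two numbers known so far, compound 2 has the lower one, but its separation from compound 1 is small: the step of a 1.4-fold lower number from compound 1 to compound 2 (0.14 log units; within the scatter) stays within the scatter, so the two compounds cannot be ranked against each other on this evidence.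

The next compound, compound 3 `C=CCn1c(=O)/c(=C\c2cccc(C)c2)[nH]c(=O)/c1=C\c1ccccc1OC`, is not yet measured. It differs from compound 2 in one place: 3-methylphenyl in place of 5-fluoro-2-methylphenyl on a double-bonded chain carbon bound to an aromatic carbon.

Among the measured compounds shown here, only one measured step bears on this change. It is the step of a 1.4-fold lower number from compound 1 to compound 2 (0.14 log units; within the scatter), which also exchanged the ring on the double-bonded chain carbon bound to an aromatic carbon and produced no movement beyond the scatter. For the measured compounds named here, with that as the sole guide, no step beyond the scatter is expected for compound 3 in this assay either, in either direction. Compound 3 is therefore expected to give about 2000 nM, with a range from 900 nM to 4500 nM. This estimate implies an expected step of a 1.1-fold higher number from compound 2 to compound 3 (0.05 log units; within the scatter), which lies within the scatter.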

Compound 3, half-maximal inhibitory concentration: 8800 nM
Compound 3: the middle estimate sits 4.4-fold (0.64 log units) below what was measured, and the stated range ends below it.
By their numbers in this assay, from the lowest: compounds 2 and 1 (each within the scatter of the next); then compound 3.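

The ring on the double-bonded chain carbon bound to an aromatic carbon is not a place where every exchange passes without effect in this assay: 3-methylphenyl gives a 4.9-fold higher number from compound 2 to compound 3 (0.69 log units; beyond the scatter) and also a 3.5-fold higher number from compound 1 to compound 3 (0.55 log units; beyond the scatter) against the two earlier rings. So 2-chlorophenyl and 5-fluoro-2-methylphenyl, which could not be ranked against each other, both stand apart from 3-methylphenyl, and the earlier silent exchange does not hold for all rings at this place. The computed counts separate the leaving and entering groups only by the fluorine, with 8 heavy atoms against 7 and neither group having hydrogen-bond donors, acceptors or a net charge.

No measurement among those given explains why the number climbs with this change. Compound 3 loses the fluorine and has its methyl named at a different ring position in the same step, so the compounds shown leave open which of these carries the effect, a question 2-methylphenyl would address, and how a phenyl bearing an amine or a carboxylic acid would behave at this place.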